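This account rests on a few compounds, and the source may have more. Where it says the series, first, only, none or still open, it means among the compounds named here.

The measured compounds:

Compound 1, `N#C/C(=C\N1CCN(C(=O)c2ccco2)C1=S)C(=O)Nc1ccc(Cl)cc1`, gives 15200 nM in a functional assay on HCT-116 cells (Homo sapiens) for inhibition, read by sulforhodamine B assay, with a stated time of 48 h; a lower number here means a stronger inhibitor of growth, a higher number a weaker inhibitor of growth.
Compound 2, `N#C/C(=C\N1CCN(C(=O)c2ccco2)C1=S)C(N)=O`, gives 21200 nM in this assay.

Both compounds share the same core and differ only at the amide-type nitrogen, where compound 1 carries a 4-chlorophenyl group and compound 2 carries a hydrogen. The step of a 1.4-fold higher number from compound 1 to compound 2 (0.14 log units; within the scatter) shows that the two numbers lie within the scatter of each other, so compound 2 cannot be set apart from compound 1 on these data.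

Compound 3, `N#C/C(=C\N1CCN(C(=O)c2ccco2)C1=S)C(=O)c1ccccc1`, is not yet measured. It differs from compound 2 by phenyl in place of amino on a carbonyl carbon. Within the data shown here, the one measured step that bears on this change, a 1.4-fold higher number from compound 1 to compound 2 (0.14 log units; within the scatter), exchanged a hydrogen for an aryl group one bond away from the same carbonyl and stayed within the scatter. On that basis the step from compound 2 to compound 3 is expected to be small, and the estimated step is a 1.4-fold lower number from compound 2 to compound 3 (0.15 log units; within the scatter), if anything leaning toward a lower number because compound 1 with its aryl group gave 15200 nM.

Compound 3 is therefore expected to give about 15000 nM, with a range from 5000 nM to 50000 nM.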

Compound 3, concentration for 50% growth inhibition: 9100 nM
Compound 3: middle estimate off by 1.6-fold (0.22 log units), on the high side; measured number inside the range.
By their numbers in this assay, from the lowest: compounds 3, 1 and 2 (each within the scatter of the next, the first and the last beyond it).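

In this assay, among these compounds, phenyl in place of amino on the carbonyl carbon gives the first step in this short series that clears the scatter (a 2.3-fold lower number from compound 2 to compound 3 (0.37 log units; beyond the scatter)), so this position does respond to what is attached there, though only modestly. Phenyl in place of (4-chlorophenyl)amino stays within the scatter (a 1.7-fold lower number from compound 1 to compound 3 (0.22 log units; within the scatter)), and since compound 1 also stays within the scatter of compound 2, the ring-bearing compounds do not form a clean group apart from the compound without a ring on this side. The change removes the amino group with its hydrogen-bond donor and brings in a six-membered aromatic ring in a single step, and no measurement here gives a reason for the shift.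

The compounds shown leave open whether a small group such as methyl on the carbonyl carbon would behave like amino or like phenyl. They also leave open whether a 4-chlorophenyl or a cyclohexyl group attached directly to that carbon would move the number further than phenyl does.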